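Swapping a ring sulfur for oxygen on a thiocarbonyl

The source may report more compounds than this note shows. Statements on the series, on what has been measured and on what is new or still open speak of the compounds shown alone.

Of the compounds shown here, two have been measured in a functional assay on A-375 cells (Homo sapiens) for cytotoxicity, read by MTT assay, with a stated time of 72 h; on this read-out lower numbers stand for stronger inhibition and higher numbers for weaker inhibition. Compound 1 `N/C(=N\NC(=S)N1CCOCC1)c1ccccn1` gives 680 nM. Compound 2 `N/C(=N\NC(=S)N1CCSCC1)c1ccc(F)cn1` gives 900 nM, the highest of the two numbers; its nearest neighbour is compound 1, and the gap between the two values lies within the scatter, so the two are indistinguishable on this read-out. Compound 1 and compound 2 differ in two places at once, so no single step can be read between them.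

Compound 3 `N/C(=N\NC(=S)N1CCOCC1)c1ccc(F)cn1` differs from compound 2 in one place: morpholin-4-yl in place of thiomorpholin-4-yl on a thiocarbonyl carbon. Both groups leaving and entering carry no donor, one acceptor and no charge, and both are six-membered non-aromatic rings. Among the compounds with values here, no measured pair shows this change on its own, so there is nothing to say its size. The expectation is a step from compound 2 to compound 3 of a 1.2-fold lower number from compound 2 to compound 3 (0.08 log units; within the scatter), no larger than the scatter and in no certain direction. Compound 3 is therefore estimated at 750 nM in this assay, within a range from 350 nM to 1600 nM.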

Compound 3, half-maximal inhibitory concentration: 1500 nM
For compound 3 the middle estimate is 2.0-fold (0.30 log units) below the measured one; low and high end bracket the measured number.
By their numbers in this assay, from the lowest: compounds 1, 2 and 3 (each within the scatter of the next, the first and the last beyond it).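

In this assay, morpholin-4-yl in place of thiomorpholin-4-yl on a thiocarbonyl carbon now has a measured pair of its own, and it gives a 1.7-fold higher number from compound 2 to compound 3 (0.22 log units; within the scatter), so in this pair the ring oxygen and the ring sulfur cannot be told apart on this read-out. The other single change, fluoro in place of hydrogen on an aromatic carbon, gives a 2.2-fold higher number from compound 1 to compound 3 (0.34 log units; beyond the scatter): a modest step, but the only single-place step among these three compounds that lies beyond the scatter. Nothing measured here accounts for either step.

As far as these compounds go, each change rests on one pair, so it remains open whether the fluoro step would look the same with thiomorpholin-4-yl on the thiocarbonyl carbon. Also open, from the compounds shown here alone, is how the read-out would respond to a chloro group in place of the fluoro on the aromatic carbon, or to a piperidin-1-yl or piperazin-1-yl ring in place of morpholin-4-yl on the thiocarbonyl carbon.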